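A few compounds are considered here, and "the series" means these few. Any claim that something is new, unique, unknown or untested is made for them only; others in the source may bear on it.

Of the compounds shown here, three from this set have been measured so far in a functional assay on IMR-32 cells (Homo sapiens) for cytotoxicity, read by sulforhodamine B assay, with a stated time of 48 h; a higher number here means a weaker inhibitor, a lower number a stronger inhibitor. Compound 1 `CC(=O)N1N=C(c2ccco2)CC1c1ccc([N+](=O)[O-])cc1` gives 35800 nM in this assay. Compound 2 `COc1ccc(C2CC(c3cccc4ccccc34)=NN2C(C)=O)c(OC)c1OC` gives 1790 nM in this assay. Compound 3 `O=CCN1N=C(c2ccc3ccccc3c2)CC1c1ccccc1[N+](=O)[O-]` gives 3360 nM in this assay, which places it second highest of the three numbers; its number and that of compound 2 lie within the usual scatter of each other, so nothing can be said about their order, whereas the number of compound 1 stands clearly higher than that of compound 3, beyond the scatter.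

The next compound, compound 4 `O=CCN1N=C(c2ccc3ccccc3c2)CC1c1ccco1`, keeps the core of compound 3 and its formylmethyl group but differs in one place: furan-2-yl in place of 2-nitrophenyl on a saturated ring carbon. Within the data shown here, no pair of measured compounds differs by exactly this change, so the size of the step has to be guessed. Among the measured compounds shown here, the only other compound carrying a furan-2-yl group, compound 1, carries it in a different place and has a nitrophenyl group elsewhere, so it offers no direct guidance. A modest move towards a higher number, at the edge of the scatter, is expected: the estimated step from compound 3 to compound 4 is a 2.1-fold higher number from compound 3 to compound 4 (0.32 log units; beyond the scatter). Compound 4 is therefore expected to give about 7000 nM in this assay, most likely between 2500 nM and 20000 nM.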

Compound 4, half-maximal inhibitory concentration: 11000 nM
Compound 4: middle estimate off by 1.6-fold (0.20 log units), on the low side; the measured number falls inside the stated range.
By their numbers in this assay, from the lowest: compounds 2 and 3 (each within the scatter of the next); then compound 4; then compound 1.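

Among these compounds, this is the first pair in the set that differs in one place only, so it gives the first direct reading of a change on this saturated ring carbon. In this assay, replacing 2-nitrophenyl with furan-2-yl, with the shared core and the formylmethyl group left untouched, gives a 3.3-fold higher number from compound 3 to compound 4 (0.52 log units; beyond the scatter), so the group at this position does affect the number and, in this pair, the 2-nitrophenyl compound is the stronger inhibitor. The change swaps a group of 9 heavy atoms for one of 5 and a six-membered aromatic ring for a five-membered one, and nothing measured here shows which of these differences, or the loss of the nitro group, matters, so no explanation can be offered for the step.

Going by these compounds, it remains open whether a plain phenyl group or a 2-aminophenyl group at this carbon would stay close to compound 3 or move towards compound 4, which would help separate the role of the nitro group from that of the ring. On these data alone, it is also open whether the same swap would give a similar step with a longer chain or an amide in place of the formylmethyl group.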